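The source may hold more compounds than are shown below. What is called first, only, known or untested is meant among the compounds shown, and "the series" means these compounds.

Measured so far in an ADME assay on HEL cells (Homo sapiens) for cytotoxicity; on this read-out higher numbers stand for lower toxicity in this test and lower numbers for higher toxicity in this test:
- compound 1 `O=C(COc1cccc2ccccc12)N/N=C/c1ccc(Cl)cc1`: 100 ug/mL
- compound 2 `C/C(=N\NC(=O)COc1cccc2ccccc12)c1ccc(O)cc1O`: 74.8 ug/mL
- compound 3 `O=C(COc1cccc2ccccc12)N/N=C/c1ccccc1Cl`: 62.7 ug/mL

Compound 2 sits between the other two on these numbers, yet its distance to compound 3 and its distance to compound 1 both lie within the scatter, so none of the three can be set apart from the others. Compound 4 `C/C(=N\NC(=O)COc1cccc2ccccc12)c1ccc(Br)cc1` has not yet been measured in this assay. Compared with compound 2, the change is 4-bromophenyl in place of 2,4-dihydroxyphenyl on a carbon with a double bond to nitrogen.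

Within the data shown here, only one measured step is available, and it concerns a different kind of change: a 1.6-fold lower number from compound 1 to compound 3 (0.20 log units; within the scatter). Among the measured compounds shown here, no measured pair swaps a 2,4-dihydroxyphenyl for a halogen-bearing phenyl, so the present change has no direct precedent. What the three compounds do show is that varied groups at this position all give numbers within the scatter of one another. On that basis compound 4 is expected to show a 1.1-fold lower number from compound 2 to compound 4 (0.03 log units; within the scatter), that is, no step beyond the scatter. The estimate for compound 4 is 70 ug/mL, with a likely range from 35 ug/mL to 140 ug/mL.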

Compound 4, half-maximal cytotoxic concentration: 15.3 ug/mL
The estimate for compound 4 lay 4.6-fold (0.66 log units) above the measured number, and the stated range ends above it.
By their numbers in this assay, from the lowest: compound 4; then compounds 3, 2 and 1 (each within the scatter of the next).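

In this assay, the group on a carbon with a double bond to nitrogen can shift the number beyond the scatter: 4-bromophenyl in place of 2,4-dihydroxyphenyl gives a 4.9-fold lower number from compound 2 to compound 4 (0.69 log units; beyond the scatter). The earlier impression that varied groups here all read alike therefore does not hold for this change, which points to higher toxicity in this test. The change removes 2 hydrogen-bond donors and 2 hydrogen-bond acceptors and brings in bromine, but no available evidence explains the drop.

These compounds do not separate the loss of the two hydroxyl groups from the arrival of bromine, a question that an unsubstituted phenyl or a 4-hydroxyphenyl in the same place could help answer. As far as these compounds go, how an aminophenyl or a carboxyphenyl would read here also remains open.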